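Swapping 4-fluorobenzyl for phenethyl on the shared core

The source may hold more compounds than are shown below. What is called first, only, known or untested is meant among the compounds shown, and "the series" means these compounds.

Among the compounds with values here, in a toxicity assay on GES1 cells (Homo sapiens) for inhibition, read by MTT assay, with a stated time of 72 h (on this read-out higher numbers stand for weaker inhibition and lower numbers for stronger inhibition), compound 3 `Cc1cc(N2CC[C@@H](C)[C@@H](N(C)c3ncnc4[nH]ccc34)C2)n2nc(SCc3ccc(F)cc3)nc2n1` gives 12300 nM, the only exact value so far. Compound 1 `Cc1cc(N2CC[C@@H](C)[C@@H](N(C)c3ncnc4[nH]ccc34)C2)n2nc(SCc3ccc(Cl)cc3)nc2n1` reads > 100000 nM, which is a limit of the assay and not a number. Compound 2 `Cc1cc(N2CC[C@@H](C)[C@@H](N(C)c3ncnc4[nH]ccc34)C2)n2nc(SCc3ccccc3Br)nc2n1` reads > 100000 nM, also a limit. Compound 4 `Cc1cc(N2CC[C@@H](C)[C@@H](N(C)c3ncnc4[nH]ccc34)C2)n2nc(SCCc3ccccc3)nc2n1` differs from compound 3 by benzyl in place of 4-fluorophenyl on a saturated chain carbon bound to a sulfur. Within the data shown here, two measured steps bear on this change, an at least 8.1-fold lower number from compound 1 to compound 3 (0.91 log units; beyond the scatter) and an at least 8.1-fold lower number from compound 2 to compound 3 (0.91 log units; beyond the scatter), so altering this group has already moved the number beyond the scatter. Only the fluoro compound has left the limit, so a rise is expected. The expected step is a 2.4-fold higher number from compound 3 to compound 4 (0.39 log units; beyond the scatter), toward weaker inhibition. The estimate for compound 4 is 30000 nM, with an expected range of 8000 nM to 100000 nM.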

Compound 4, half-maximal inhibitory concentration: 66200 nM
Compound 4: middle estimate off by 2.2-fold (0.34 log units), on the low side; low and high end bracket the measured number.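

Phenethyl on the sulfur is a second group that gives an exact number rather than a limit, and it reads toward weaker inhibition: a 5.4-fold higher number from compound 3 to compound 4 (0.73 log units; beyond the scatter). Against the two halogenated benzyl compounds only floors can be read, an at least 1.5-fold lower number from compound 2 to compound 4 (0.17 log units; that floor lies within the scatter) and an at least 1.5-fold lower number from compound 1 to compound 4 (0.17 log units; that floor lies within the scatter), so compound 4 cannot be separated from them. Those comparisons stay open at the top: the limit of > 100000 nM in this assay, at which 2 of the 4 values shown sit.

Compound 4 lengthens the chain and loses the fluorine in one step, and the two changes remain unseparated. On these data alone, whether a 4-fluorophenethyl group, or a chain ending in an amine, would read nearer compound 3 or compound 4 remains open.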